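A Sulfonyl Group Returns to the Ring Nitrogen

A few compounds are considered here, and "the series" means these few. Any claim that something is new, unique, unknown or untested is made for them only; others in the source may bear on it.

Measured so far:
Compound 1 `COC(=O)c1ccc(C2SCC(=O)N2c2ccc(N3CCN(Cc4cccc(C)c4)CC3)cn2)c(OC)c1` gives > 100000 nM in a functional assay on K562 cells (Homo sapiens) for antiproliferative activity, read by MTT assay and trypan blue exclusion, with a stated time of 72 h (on this read-out higher numbers stand for weaker inhibition and lower numbers for stronger inhibition), which is a limit of the assay, not a number.
Compound 2 `COC(=O)c1ccc(C2SCC(=O)N2c2ccc(N3CCN(S(=O)(=O)c4cc(Cl)ccc4Cl)CC3)cn2)c(OC)c1` gives > 100000 nM in this assay, again a limit of the assay.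
Compound 3 `COC(=O)c1ccc(C2SCC(=O)N2c2ccc(N3CCNCC3)cn2)c(OC)c1` gives 15200 nM in this assay.

Among the compounds with values here, compound 3 is thus the only compound with a real number; the other two sit at the limit of > 100000 nM in this assay, at which 2 of the 3 values shown sit. Compound 3 carries a bare hydrogen on the ring nitrogen where compound 1 carries 3-methylbenzyl and compound 2 carries (2,5-dichlorophenyl)sulfonyl. The step of an at least 6.5-fold lower number from compound 1 to compound 3 (0.81 log units; beyond the scatter) and the step of an at least 6.5-fold lower number from compound 2 to compound 3 (0.81 log units; beyond the scatter) point the same way: stripping the group from that nitrogen lowers the number, and by how much cannot be said, since the starting values are limits.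

Compound 4 `COC(=O)c1ccc(C2SCC(=O)N2c2ccc(N3CCN(S(=O)(=O)c4c(C)cc(C)cc4C)CC3)cn2)c(OC)c1` goes back in the other direction: (2,4,6-trimethylphenyl)sulfonyl in place of hydrogen on an amine nitrogen in a ring. This most resembles the sulfonyl of compound 2, so the step from compound 2 to compound 3, read in reverse, is the guide, and a rise in the number is expected, most likely back to a limit. For compound 4 the expected step is a 6.6-fold higher number from compound 3 to compound 4 (0.82 log units; beyond the scatter). Compound 4 is therefore estimated at 100000 nM, within 40000 nM to 300000 nM.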

Compound 4, half-maximal inhibitory concentration: 53500 nM
Beside the measured number, compound 4's estimate is 1.9-fold (0.27 log units) above it; the range from low to high includes it.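

Within the data shown here, compound 4 is the first compound here with a group on the ring nitrogen that gives a real number rather than a limit, so a large group at this nitrogen does not always reach the limit, yet placing (2,4,6-trimethylphenyl)sulfonyl there in place of hydrogen still gives a 3.5-fold higher number from compound 3 to compound 4 (0.55 log units; beyond the scatter). With 2,4,6-trimethylphenyl in place of 2,5-dichlorophenyl on the sulfonyl sulfur the result is an at least 1.8-fold lower number from compound 2 to compound 4 (0.27 log units; that floor lies within the scatter), and with (2,4,6-trimethylphenyl)sulfonyl in place of 3-methylbenzyl it is an at least 1.8-fold lower number from compound 1 to compound 4 (0.27 log units; that floor lies within the scatter), so neither comparison alone shows a real difference. Both of these comparisons start from a limit, not a number: the limit of > 100000 nM in this assay, at which 2 of the 4 values shown sit.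

The compounds shown leave open how small a group on this nitrogen must be for the number to stay close to that of the bare hydrogen, as a methyl or an acetyl group on the same nitrogen would show. They also leave open whether the methyl ester on the shared core matters, which a carboxylic acid or an amide in its place would test.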